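This account rests on a few compounds, and the source may have more. Where it says the series, first, only, none or still open, it means among the compounds named here.

Measured so far:
- compound 1, `Nc1ccccc1NC(=O)c1ccc(CSC(=S)N2CCc3cc([N+](=O)[O-])ccc32)cc1`: 16.9%
- compound 2, `CC1CCN(C(=S)SCc2ccc(C(=O)Nc3ccccc3N)cc2)CC1`: 32.7%
- compound 3, `Nc1ccccc1NC(=O)c1ccc(CSC(=S)N2CCN(Cc3ccncc3)CC2)cc1`: 33.1%

All three numbers come from a functional assay on A-375 cells (Homo sapiens) for antiproliferative activity, read by CCK-8 assay, with a stated time of 72 h, tested at 2 uM; a higher number here means a stronger effect of the compound at the concentration tested, a lower number a weaker effect. Compound 3 carries the largest of the three, yet its value and that of compound 2 lie within the usual scatter of each other, so no order can be read between them; only compound 1 sits clearly lower in this assay. The next compound, compound 4 `Nc1ccccc1NC(=O)c1ccc(CSC(=S)N2CCN(Cc3ccccc3)CC2)cc1`, differs from compound 3 in one place: phenyl in place of pyridin-4-yl on a saturated chain carbon bound to an amine nitrogen in a ring. Going by the values given here, no measured pair shows this exchange, so the size of the step is unknown; a step no larger than the scatter, in either direction, is expected. Compound 4 is therefore estimated at 31%, range 18% to 45%, an expected step of a number 2.1 percentage points lower from compound 3 to compound 4 (within the scatter).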

Compound 4, a percentage reported as inhibition, at one concentration (the size of the read-out at that concentration, not a potency): 10.6%
The estimate for compound 4 lay 20.4 percentage points above the measured number; measured number below the stated range.
By their numbers in this assay, from the lowest: compounds 4 and 1 (each within the scatter of the next); then compounds 2 and 3 (each within the scatter of the next).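

In this assay, phenyl in place of pyridin-4-yl on a saturated chain carbon bound to an amine nitrogen in a ring gives a number 22.5 percentage points lower from compound 3 to compound 4 (beyond the scatter). This place in the series is therefore sensitive to a change as small as a ring nitrogen replaced by carbon, with the hydrogen-bond acceptor of pyridin-4-yl lost. Nothing available explains this step.

Whether the ring nitrogen must sit as in pyridin-4-yl remains open, as pyridin-3-yl and pyridin-2-yl do not appear among these compounds. Also open, from the compounds shown here alone, is how a longer chain between the two rings would read.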